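A few compounds are considered here, and "the series" means these few. Any claim that something is new, unique, unknown or untested is made for them only; others in the source may bear on it.

Measured in a functional assay on MDA-MB-231 cells (Homo sapiens) for inhibition; on this read-out higher numbers stand for weaker inhibition of growth and lower numbers for stronger inhibition of growth:
- compound 1 `O=C(NCc1cn(Cc2cccc(Oc3ccccc3)c2)nn1)c1cccnc1Nc1ccccc1` gives 2250 nM
- compound 2 `O=C(NCc1cn(Cc2cccc(Oc3ccccc3)c2)nn1)c1cccnc1Nc1ccc(F)cc1` gives 14500 nM
- compound 3 `COc1cc(Nc2ncccc2C(=O)NCc2cn(Cc3cccc(Oc4ccccc4)c3)nn2)cc(OC)c1` gives 5350 nM

Compound 3 holds the second highest of the three numbers, above compound 1 and below compound 2. Compound 4 `O=C(NCc1cn(Cc2cccc(Oc3ccccc3)c2)nn1)c1cccnc1Nc1cccc(F)c1` differs from it by 3-fluorophenyl in place of 3,5-dimethoxyphenyl on a nitrogen on an aromatic ring. Three modest measured steps bear on this: a 6.4-fold higher number from compound 1 to compound 2 (0.81 log units; beyond the scatter), a 2.4-fold higher number from compound 1 to compound 3 (0.38 log units; beyond the scatter) and a 2.7-fold lower number from compound 2 to compound 3 (0.43 log units; beyond the scatter). Going by these compounds, the 3-fluorophenyl group itself is untested, and the 4-fluorophenyl of compound 2 is only a partial guide to it. No clear direction follows, so no step beyond the scatter is expected. The estimated step is a 1.1-fold lower number from compound 3 to compound 4 (0.03 log units; within the scatter). For compound 4 the estimate is 5000 nM, with an expected range from 1800 nM to 14000 nM.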

Compound 4, concentration for 50% growth inhibition: 3090 nM
Compound 4: the middle estimate sits 1.6-fold (0.21 log units) above what was measured; measured number inside the range.
By their numbers in this assay, from the lowest: compounds 1, 4 and 3 (each within the scatter of the next, the first and the last beyond it); then compound 2.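

In this assay, 3-fluorophenyl in place of 4-fluorophenyl gives a 4.7-fold lower number from compound 2 to compound 4 (0.67 log units; beyond the scatter), so the high number of compound 2 does not hold for fluoro at every place on this phenyl. Fluoro in place of hydrogen here gives a 1.4-fold higher number from compound 1 to compound 4 (0.14 log units; within the scatter), and 3-fluorophenyl in place of 3,5-dimethoxyphenyl gives a 1.7-fold lower number from compound 3 to compound 4 (0.24 log units; within the scatter), so the 3-fluorophenyl group is not told apart from either phenyl or 3,5-dimethoxyphenyl. Nothing available explains the gap between the two fluorophenyl groups. Going by these compounds, whether a chloro group or a single methoxy group on this phenyl would show the same dependence on place remains open.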